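The source may report more compounds than this note shows. Statements on the series, on what has been measured and on what is new or still open speak of the compounds shown alone.

In a functional assay on HeLa cells (Homo sapiens) for cytotoxicity, read by MTT assay, with a stated time of 48 h (on this read-out higher numbers stand for weaker inhibition and lower numbers for stronger inhibition), compound 1 `C=C/C(C)=C/CC/C(C)=C/c1cc(C(=O)O)co1` gives 80400 nM and compound 2 `C=C/C(C)=C\CC/C(C)=C/c1cc(C(=O)OC)co1` gives 59400 nM with the two values lying within the usual scatter of each other. Compound 3 `C=C/C(C)=C/CC/C(C)=C/c1cc(C(=O)OC)co1` remains unmeasured, and its change from compound 2 reads: the two compounds have the same atoms and bonds and differ only in configuration as drawn: 1 of 2 stereo elements differ; a double bond is drawn Z in compound 2 and E in compound 3 (no atoms leave or enter). For the measured compounds named here, no measured pair shows a change of this kind, so no shift beyond the scatter is expected in this assay in either direction. The estimated 1.0-fold higher number from compound 2 to compound 3 (0.00 log units; within the scatter) is expected to stay within the scatter. For compound 3 the expected value is 60000 nM with an estimated range from 30000 nM to 110000 nM in this read-out.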

Compound 3, half-maximal inhibitory concentration: 35500 nM
The estimate for compound 3 lay 1.7-fold (0.23 log units) above the measured number; low and high end bracket the measured number.
By their numbers in this assay, from the lowest: compounds 3, 2 and 1 (each within the scatter of the next, the first and the last beyond it).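

In this assay drawing a double bond E rather than Z gives no shift beyond the scatter (a 1.7-fold lower number from compound 2 to compound 3 (0.22 log units; within the scatter)). For the compounds shown here, with the double bonds drawn alike, methyl in place of hydrogen on an oxygen next to a carbonyl group gives the first step beyond the scatter, modest in size (a 2.3-fold lower number from compound 1 to compound 3 (0.36 log units; beyond the scatter)). The stereo comparison is clean on one point: the fact that compounds 2 and 3 differ only in the configuration as drawn. On these data alone, whether an amide or a longer chain at that carbonyl would move the number stays open, as does the effect of the second stereo element.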